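The source may report more compounds than this note shows. Statements on the series, on what has been measured and on what is new or still open speak of the compounds shown alone.

Compound 2 `COc1cc(/C=C2\CN(C)C/C(=C\c3ccc(Cl)cc3)C2=O)cc(OC)c1` shares its core with compound 1 `COc1cc(/C=C2\CN(C)C/C(=C\c3ccccc3F)C2=O)cc(OC)c1` and compound 3 `COc1cc(/C=C2\CN(C)C/C(=C\c3cccc([N+](=O)[O-])c3)C2=O)cc(OC)c1`. In an ADME assay on L02 cells (Homo sapiens) for cytotoxicity, read by MTT assay, with a stated time of 24 h (a higher number here means a weaker inhibitor, a lower number a stronger inhibitor), compound 2 gives 18900 nM, the highest of the three numbers shown, though compound 1 gives 11900 nM and compound 3 gives 10800 nM, and the steps of a 1.6-fold higher number from compound 1 to compound 2 (0.20 log units; within the scatter) and a 1.8-fold lower number from compound 2 to compound 3 (0.24 log units; within the scatter) both stay within the scatter. Compound 4 `COc1cc(/C=C2\CN(C)C/C(=C\c3ccc(Cl)cc3)C2=O)cc(OC)c1OC` differs from compound 2 by methoxy in place of hydrogen on an aromatic carbon. For the measured compounds named here, no measured step touches this ring; the known steps change the other aryl group and none leaves the scatter, so no shift beyond the scatter is expected from compound 2 to compound 4. Compound 4 is therefore estimated at 17000 nM, between 8000 nM and 36000 nM, an expected step of a 1.1-fold lower number from compound 2 to compound 4 (0.05 log units; within the scatter) in this assay.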

Compound 4, half-maximal inhibitory concentration: 14000 nM
Compound 4: the middle estimate sits 1.2-fold (0.08 log units) above what was measured; measured number inside the range.
By their numbers in this assay, from the lowest: compounds 3, 1, 4 and 2 (each within the scatter of the next).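

Methoxy in place of hydrogen, ortho to two methoxy groups and para to a large group, is the first change shown on this ring, and in this assay it gives a 1.4-fold lower number from compound 2 to compound 4 (0.13 log units; within the scatter). This position therefore takes one added methoxy without a shift beyond the scatter, in the setting of compound 2 only. No evidence on the origin of this small step is available. On these data alone, whether an amine, a carboxylic acid or a longer alkoxy chain at this position would leave the scatter remains open. So does whether methoxy here behaves alike with 2-fluorophenyl or 3-nitrophenyl on the other side.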